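This account rests on a few compounds, and the source may have more. Where it says the series, first, only, none or still open, it means among the compounds named here.

Of the compounds shown here, three sharing one core have been measured in a functional assay on SK-MEL-28 cells (Homo sapiens) for cytotoxicity, read by CCK-8 assay, with a stated time of 24 h; a higher number here means a weaker inhibitor, a lower number a stronger inhibitor: compound 1 (`COc1ccccc1Oc1c(N)nc(-c2cccc(C)c2)nc1Cl`) gives 54000 nM, compound 2 (`COc1ccccc1Oc1c(N)nc(-c2ccc(F)cc2)nc1Cl`) gives 31900 nM and compound 3 (`COc1ccccc1Oc1c(N)nc(-c2cccc(Cl)c2)nc1Cl`) gives 19400 nM. Compound 3 stands nearest to compound 2 and furthest from compound 1. The data show a 2.8-fold lower number from compound 1 to compound 3 (0.44 log units; beyond the scatter), while a 1.6-fold lower number from compound 2 to compound 3 (0.22 log units; within the scatter) and a 1.7-fold lower number from compound 1 to compound 2 (0.23 log units; within the scatter) are smaller.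

Compound 4 (`COc1ccccc1Oc1c(N)nc(-c2ccc(Cl)cc2)nc1Cl`) carries the same atoms as compound 3, joined differently: 4-chlorophenyl in place of 3-chlorophenyl on an aromatic carbon. In words, this is 4-chlorophenyl in place of 3-chlorophenyl on an aromatic carbon. Within the data shown here, no measured pair changes the chlorine position alone. The closest guide is a 1.6-fold lower number from compound 2 to compound 3 (0.22 log units; within the scatter), which exchanges 4-fluorophenyl for 3-chlorophenyl and stays within the scatter, so no step beyond the scatter is expected in this assay. The estimate amounts to a 1.2-fold higher number from compound 3 to compound 4 (0.09 log units; within the scatter), an expected step with no firm direction. Compound 4 is expected at 24000 nM, with an estimated range from 12000 nM to 50000 nM.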

Compound 4, half-maximal inhibitory concentration: 120 nM
Compound 4: the middle estimate sits 200-fold (2.30 log units) above what was measured; the measured number lies below the stated range.
By their numbers in this assay, from the lowest: compound 4; then compounds 3, 2 and 1 (each within the scatter of the next, the first and the last beyond it).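

In this assay, among these compounds, moving the chlorine alone, with 4-chlorophenyl in place of 3-chlorophenyl, gives a 160-fold lower number from compound 3 to compound 4 (2.21 log units; beyond the scatter) and shows that the placement of one atom on this aryl group can matter far more than the earlier steps suggested. The identity of the group matters as well: chloro in place of fluoro gives a 270-fold lower number from compound 2 to compound 4 (2.42 log units; beyond the scatter) and 4-chlorophenyl in place of 3-methylphenyl gives a 450-fold lower number from compound 1 to compound 4 (2.65 log units; beyond the scatter), so the gain belongs to 4-chlorophenyl specifically among the groups shown. Nothing available here explains why this one change has so large an effect.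

Going by these compounds, whether 4-bromophenyl or 4-methoxyphenyl would keep a number this low remains open. So does whether the gain would survive replacing the amino group of the shared core with a methylamino group.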